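Methoxy in Place of Chloro: Estimating Compound 4

The compounds below may be only part of what the source reports. "The series", "measured", "known", "first", "only" and "open" are said of these compounds alone.

Compound 1 `COc1ccc(CS(=O)(=O)/C=C/c2ccc(F)cc2)cc1`: 2500 nM
Compound 2 `COc1ccc(CS(=O)(=O)/C=C/c2ccccc2OC)cc1`: 5000 nM
Compound 3 `COc1ccc(CS(=O)(=O)/C=C/c2ccc(F)cc2Cl)cc1`: 2500 nM

In a functional assay on H157 cells (Homo sapiens) for antiproliferative activity, read by trypan blue exclusion (a higher number here means a weaker inhibitor, a lower number a stronger inhibitor), compound 3 gives 2500 nM, level with compound 1 and, together with it, the lowest of the three numbers; its nearest neighbour is compound 1 and its furthest compound 2, both within the scatter. For the measured compounds named here, the only single-change step measured, no change at the digits printed from compound 1 to compound 3 (within the scatter), shows that adding chloro leaves the number unchanged. Compound 4 `COc1ccc(CS(=O)(=O)/C=C/c2ccc(F)cc2OC)cc1` differs from compound 3 by methoxy in place of chloro on an aromatic carbon. Going by the values given here, no measured step swaps methoxy for chloro. Compound 2, which also carries a methoxy but no fluoro, gives 5000 nM, a number still within the scatter of compound 3, while compound 1 and compound 3 together show that the chloro itself made no measurable difference. The step of a 1.4-fold higher number from compound 3 to compound 4 (0.15 log units; within the scatter) is therefore expected to be small, if anything toward a slightly higher number. Compound 4 is estimated at 3500 nM, with a range from 1500 nM to 8000 nM.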

Compound 4, half-maximal inhibitory concentration: 20000 nM
Estimate against measurement, compound 4: 5.7-fold (0.76 log units) below, and the stated range ends below it.
By their numbers in this assay, from the lowest: compounds 1, 3 and 2 (each within the scatter of the next); then compound 4.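

In this assay, this position on the aromatic ring, ortho to a large group, proves sensitive to what stands on it: chloro in place of hydrogen left the number flat, with no change at the digits printed from compound 1 to compound 3 (within the scatter), but methoxy in place of chloro gives an 8.0-fold higher number from compound 3 to compound 4 (0.90 log units; beyond the scatter), and methoxy in place of hydrogen gives an 8.0-fold higher number from compound 1 to compound 4 (0.90 log units; beyond the scatter). Fluoro in place of hydrogen, with methoxy already present, gives a 4.0-fold higher number from compound 2 to compound 4 (0.60 log units; beyond the scatter), so among these four compounds the clearly higher number appears only where methoxy and fluoro stand together. Nothing available explains these steps.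

As far as these compounds go, whether an ethoxy or a hydroxyl group at this position would behave like methoxy or like chloro remains open. So does whether methoxy would carry the same penalty with an amine in place of the fluoro group.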